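The compounds below may be only part of what the source reports. "The series", "measured", "known", "first", "only" and "open" are said of these compounds alone.

Measured compounds:
compound 1 `CN(C(=O)NC(=O)c1ccccc1F)c1nc(C(F)(F)F)c(C(=O)N/N=C/c2cc(C(F)(F)F)cc(C(F)(F)F)c2)s1`, 4.98 ug/mL
compound 2 `CN(C(=O)NC(=O)c1ccc(C(F)(F)F)cc1)c1nc(C(F)(F)F)c(C(=O)N/N=C/c2cc(C(F)(F)F)cc(C(F)(F)F)c2)s1`, 5.78 ug/mL
compound 3 `CN(C(=O)NC(=O)c1c(F)cccc1F)c1nc(C(F)(F)F)c(C(=O)N/N=C/c2cc(C(F)(F)F)cc(C(F)(F)F)c2)s1`, 5.62 ug/mL

In a functional assay on HeLa cells (Homo sapiens) for inhibition, read by MTT assay, with a stated time of 72 h (a higher number here means a weaker inhibitor, a lower number a stronger inhibitor), compound 1 gives the lowest of the three numbers, but its nearest neighbour compound 3 and its furthest neighbour compound 2 both lie within the scatter of it, so the three are not ordered. The steps recorded so far, a 1.2-fold higher number from compound 1 to compound 2 (0.06 log units; within the scatter), a 1.1-fold higher number from compound 1 to compound 3 (0.05 log units; within the scatter) and a 1.0-fold lower number from compound 2 to compound 3 (0.01 log units; within the scatter), all concern the acyl portion and none moved the number beyond the scatter.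

Compound 4 `CN(C(=O)NC(=O)c1ccccc1F)c1nc(C(F)(F)F)c(C(=O)N/N=C/c2cccc(C(F)(F)F)c2)s1` differs from compound 1 by hydrogen in place of trifluoromethyl on an aromatic carbon. Among the measured compounds shown here, no measured step touches this part of the shared core, so nothing here shows how the number responds to it. The expectation therefore rests on the flat picture of compounds 1 to 3: a step of a 1.3-fold higher number from compound 1 to compound 4 (0.12 log units; within the scatter), not clearly beyond the scatter, with a wide range. Compound 4 is estimated at 6.5 ug/mL, between 3 ug/mL and 15 ug/mL.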

Compound 4, half-maximal inhibitory concentration: 19.1 ug/mL
The estimate for compound 4 lay 2.9-fold (0.47 log units) below the measured number; measured number outside the range, above it.
By their numbers in this assay, from the lowest: compounds 1, 3 and 2 (each within the scatter of the next); then compound 4.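

In this assay, among the compounds shown here, hydrogen in place of trifluoromethyl on this six-membered aromatic ring of carbon only gives a 3.8-fold higher number from compound 1 to compound 4 (0.58 log units; beyond the scatter) and is the first step beyond the scatter. This position therefore moves the number, whereas the acyl changes among compounds 1, 2 and 3 did not. No available measurement bears on the cause of this step.

On these data alone, it remains open whether a chlorine, a methoxy group or an amine at this position would keep the number close to that of compound 1. As far as these compounds go, it is also open whether the step would be the same with the acyl portions of compound 2 or compound 3.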